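A few compounds are considered here, and "the series" means these few. Any claim that something is new, unique, unknown or untested is made for them only; others in the source may bear on it.

Measured in an ADME assay on cells (Erythrocyte, Homo sapiens), read by spectrophotometry and hemolysis, with a stated time of 24 h; on this read-out higher numbers stand for weaker inhibition and lower numbers for stronger inhibition:
compound 1 `CC1(C)[N+]([O-])=c2ccc(COc3ccc(C=O)cc3)cc2=[N+]1[O-]`: 65 uM
compound 2 `CC1(C)[N+]([O-])=c2ccc(COc3ccc(/C=N/NC(N)=S)cc3)cc2=[N+]1[O-]`: "nd(insoluble)" (no result reported)
compound 3 `CC1(C)[N+]([O-])=c2ccc(COc3ccc(/C=N/NC(=S)Nc4ccccc4)cc3)cc2=[N+]1[O-]`: < 50 uM

Only compound 1 has a single number, 65 uM. Compound 2 has no result to compare, as its entry shows: "nd(insoluble)" (no result reported). Compound 3 is known only through a limit, < 50 uM, which is not a number. Going by these compounds, that places compound 3 at the limit of < 50 uM in this assay, at which 1 of the 3 values shown sits, so its exact position in this assay remains open.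

Compound 4 `CC1(C)[N+]([O-])=c2ccc(COc3ccc(/C=N/NC(N)=O)cc3)cc2=[N+]1[O-]` has not yet been measured. It differs from compound 3 at one place, on an amine nitrogen: a group of 3 heavy atoms (1 carbon, 1 nitrogen, 1 oxygen; no ring) in place of a group of 9 heavy atoms (7 carbon, 1 nitrogen, 1 sulfur; one six-membered aromatic ring of carbon only), on an amine nitrogen. The incoming group is carbamoyl, and it brings no ring. Going by the values given here, no measured pair in this small set shows what such an exchange does, so any forecast is loose.

A modest shift towards a higher number, which would mean weaker inhibition, is expected, and the estimated change is an at least 1.2-fold higher number from compound 3 to compound 4 (0.07 log units; that floor lies within the scatter). Among the compounds with values here, this expectation leans on compound 1, whose value of 65 uM is the only full number available. The expected value for compound 4 is 60 uM, with an estimated range from 20 uM to 180 uM.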

Compound 4, concentration for 50% inhibition: > 200 uM
Compound 4 was reported as a limit; the forecaster's own chance of this, stated with the estimate: 35%; at least 3.3-fold (0.52 log units) between middle value and limit.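

In this assay, putting carbamoyl on the amine nitrogen in place of the group of 9 heavy atoms, with its six-membered aromatic ring and its sulfur, gives an at least 4.0-fold higher number from compound 3 to compound 4 (0.60 log units; beyond the scatter), so the group at this place clearly matters for the read-out. Compared with the core of compound 1, the exchange of the group on the aromatic carbon gives an at least 3.0-fold higher number from compound 1 to compound 4 (0.48 log units; beyond the scatter), so this carbamoyl end also separates compound 4 from the only full number in the set. The result for compound 4 is a limit and not a number, so these steps give only a minimum size: the limit of > 200 uM in this assay, at which 1 of the 4 values shown sits.

The exchange removes the ring and replaces sulfur with oxygen at once, and the steps to compound 2, the sulfur partner of compound 4 without the ring, cannot be read, so the two parts of the change stay unseparated. Going by these compounds, whether a smaller addition to that nitrogen, such as a methyl group, or a longer chain would keep the number high also remains open.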